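From Cyano to Bromo: an Expectation for Compound 4

This account rests on a few compounds, and the source may have more. Where it says the series, first, only, none or still open, it means among the compounds named here.

Compound 1 `CC(O)(C(=O)Nc1ccc(C#N)c(S(=O)(=O)c2ccccc2)c1)C(F)(F)F`: in a functional assay (Cavia porcellus) with sulfonylurea receptors; K-ATP channels (Homo sapiens) as the target (on this read-out higher numbers stand for weaker inhibition and lower numbers for stronger inhibition), compound 1 gives 2600 nM.
Compound 2 `CO/N=C(/c1ccccc1)c1ccc(NC(=O)C(C)(O)C(F)(F)F)cc1`: in this assay compound 2 gives > 30000 nM, which is a limit and not a number.
Compound 3 `CC(O)(C(=O)Nc1ccc(C(=O)c2ccccc2)cc1C#N)C(F)(F)F`: in this assay compound 3 gives 3800 nM.

All three share the same hydroxy trifluoromethyl amide attached to a benzene ring. Of the two numbers measured, compound 3 has the higher one; compound 1 stands nearest, and the gap between compound 3 and compound 1 lies within the scatter, so the two cannot be ranked against each other. Compound 2 reached only a limit.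

Compound 4 `CC(O)(C(=O)Nc1ccc(C(=O)c2ccccc2)cc1Br)C(F)(F)F` differs from compound 3 in a single place: bromo in place of cyano on an aromatic carbon. For the measured compounds named here, no measured pair shows this exchange, so there is no measured step to set its size. The expected step in this assay is small, not beyond the scatter and with no clear direction, namely a 1.1-fold lower number from compound 3 to compound 4 (0.04 log units; within the scatter). Compound 4 is therefore expected to give about 3500 nM, estimated to fall between 1200 nM and 12000 nM.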

Compound 4, half-maximal inhibitory concentration: > 30000 nM
Compound 4: no number, only a limit (the forecaster's own chance of this, stated with the estimate: 10%); middle value at least 8.5-fold (0.93 log units) from the limit.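

For the compounds shown here, this position, ortho to a large group and meta to a benzoyl group, is the first place where a single exchange can be read, and it is not a neutral one: in this assay, bromo in place of cyano gives an at least 7.8-fold higher number from compound 3 to compound 4 (0.89 log units; beyond the scatter). The value of compound 4, > 30000 nM, is a limit and not a number. The step therefore gives only the smallest size this change can have, and the same limit recurs in the set: the limit of > 30000 nM in this assay, at which 2 of the 4 values shown sit.

A chloro group, a methyl group or an amine at this position would show whether cyano is unusually well suited here or bromo is unusually poorly suited. The compounds shown also leave open whether bromo in place of cyano would have a similar effect on the core of compound 1, which also carries a cyano group.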